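The compounds below may be only part of what the source reports. "The series", "measured", "known", "first", "only" and "open" are said of these compounds alone.

Compound 1, `CC1=CC[C@H]2[C@@H]1CC=C(C)[C@@H](CC[C@H]1[C@]3(C)CC[C@H](OCc4ccccc4)C(C)(C)O[C@H]3CC[C@@]1(C)O)C2(C)C`: > 50000 nM
Compound 2, `CC1(C)O[C@H]2CC[C@@](C)(O)[C@@H](CC[C@@H]3C(CO)=CC[C@H]4[C@H](CC[C@]4(C)O)C3(C)C)[C@]2(C)CCC1=O`: > 50000 nM

In a functional assay on MCF7 cells (Homo sapiens) for antiproliferative activity, read by MTT assay, with a stated time of 72 h (on this read-out higher numbers stand for weaker inhibition and lower numbers for stronger inhibition), compound 1 gives > 50000 nM, which is a limit of the assay rather than a number. Compound 2 gives > 50000 nM in this assay, likewise a limit. Both results sit at the same point, (the limit of > 50000 nM in this assay, at which 2 of the 2 values shown sit), so compound 2 stands at the limit, with nothing to separate it from compound 1 on the numbers shown.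

Compound 3, `CC1(C)O[C@H]2CC[C@@](C)(O)[C@@H](CC[C@@H]3C(C=O)=CC[C@H]4[C@H](CC[C@]4(C)O)C3(C)C)[C@]2(C)CCC1=O`, differs from compound 2 by formyl in place of hydroxymethyl on a double-bonded ring carbon. Among the compounds with values here, no step between two measured compounds is available to calibrate such a change. The new group is expected to move the result little, if at all: the step is expected to be a number no higher from compound 2 to compound 3 (the limit leaves the size open), none beyond the scatter. Compound 3 is therefore estimated at 50000 nM, in a range from 15000 nM to 200000 nM, most probably again reported only as a limit.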

Compound 3, half-maximal inhibitory concentration: > 50000 nM
Compound 3: a limit, no number; the forecaster's own chance of this, stated with the estimate: 70%; the middle value sits exactly at the limit.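

Compound 3 gives > 50000 nM in this assay, which is a limit and not a number. No step from compound 2 to compound 3 can therefore be read: the limit of > 50000 nM in this assay, at which 3 of the 3 values shown sit.

The compounds shown leave open what true value lies behind each limit, and whether any change to the shared core would give a measurable number in this assay.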